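A few compounds are considered here, and "the series" means these few. Any claim that something is new, unique, unknown or untested is made for them only; others in the source may bear on it.

Of the compounds shown here, three have been measured in an ADME assay on cells (Homo sapiens) for activation; a lower number here means that less compound is tolerated, a higher number that more compound is tolerated. Compound 1 `COc1ccc2c(OCC[C@@H]3NC(=O)N(C)CCCC/C=C\[C@@H]4C[C@@]4(C(=O)NS(=O)(=O)C4(C)CC4)NC3=O)cc(-c3nc(C(C)C)cs3)nc2c1` gives 6500 nM, compound 3 `COc1ccc2c(OCC[C@@H]3NC(=O)N(C)CCCC/C=C\[C@@H]4C[C@@]4(C(=O)NS(=O)(=O)C4(C)CC4)NC3=O)cc(-c3nc(C(C)C)cs3)nc2c1Br` gives 28300 nM, and compound 2 `COc1ccc2c(OCC[C@@H]3NC(=O)N(C)CCCC/C=C\[C@@H]4C[C@@]4(C(=O)NS(=O)(=O)C4(F)CC4)NC3=O)cc(-c3nc(C(C)C)cs3)nc2c1Cl` gives 51400 nM. Compound 2 therefore stands clearly above compound 1, beyond the scatter, while its value and that of compound 3 lie within the scatter of each other.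

Compound 4 `CCC1(S(=O)(=O)NC(=O)[C@@]23C[C@H]2/C=C\CCCCN(C)C(=O)N[C@@H](CCOc2cc(-c4nc(C(C)C)cs4)nc4c(Cl)c(OC)ccc24)C(=O)N3)CC1` keeps the core of compound 2 and changes one group: ethyl in place of fluoro on a saturated ring carbon. Among the measured compounds shown here, no measured step isolates this change. For the measured compounds named here, the only single-place step, a 4.4-fold higher number from compound 1 to compound 3 (0.64 log units; beyond the scatter), is modest and concerns bromo in place of hydrogen on an aromatic carbon, so it bears on the change only indirectly. More relevant is that compound 2 and compound 3 differ at this same ring carbon as well as on the core, yet compound 3, at 28300 nM, remains within the scatter of compound 2. A large shift is therefore not expected, though a slight move downward is possible. The expected change is a 1.4-fold lower number from compound 2 to compound 4 (0.15 log units; within the scatter), an estimated step that stays within the scatter. For compound 4 the estimated value is 36000 nM, with an expected range from 14000 nM to 80000 nM.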

Compound 4, half-maximal cytotoxic concentration: 49300 nM
For compound 4 the middle estimate is 1.4-fold (0.14 log units) below the measured one, and the stated range covers the measured number.
By their numbers in this assay, from the lowest: compound 1; then compounds 3, 4 and 2 (each within the scatter of the next).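

Ethyl in place of fluoro on a saturated ring carbon gives a 1.0-fold lower number from compound 2 to compound 4 (0.02 log units; within the scatter) in this assay, the first step shown that isolates this position of the three-membered ring. On the core of compound 2, the change from 1-fluorocyclopropyl to 1-ethylcyclopropyl, with one fluorine leaving and two carbons entering, therefore leaves the half-maximal cytotoxic concentration within the scatter. At this position and on this core, the number does not separate these two groups, and nothing supplied here gives a reason for that.

Only fluoro and ethyl can be compared directly at this ring carbon with the rest of the structure held constant, so this reading covers just that one pair on the core of compound 2. Going by these compounds, it remains open whether an amine, a carboxylic acid or a longer chain such as butyl on the same carbon would also keep the number within the scatter of compound 2, and whether ethyl in place of fluoro would read the same way on the core of compound 1.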